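A few compounds are considered here, and "the series" means these few. Any claim that something is new, unique, unknown or untested is made for them only; others in the source may bear on it.

Among the compounds with values here, compound 3 `Oc1ccc(-c2cc(-c3ccccc3C(F)(F)F)cc(-c3cccc(O)c3)n2)cc1` gives 2750 nM in a functional assay on DU-145 cells (Homo sapiens) for inhibition (a lower number here means a stronger inhibitor, a higher number a weaker inhibitor), and holds the lowest of the three numbers measured so far; compound 2 `Oc1ccc(-c2cc(-c3ccc(F)cc3)cc(-c3ccc(O)cc3)n2)cc1` gives 6030 nM and compound 1 `Oc1ccc(-c2cc(-c3ccccc3F)cc(-c3ccc(O)cc3)n2)cc1` gives 7780 nM. Compound 4 `Oc1ccc(-c2cc(-c3ccccc3C(F)(F)F)cc(-c3ccc(O)cc3)n2)cc1` differs from compound 3 by 4-hydroxyphenyl in place of 3-hydroxyphenyl on an aromatic carbon, next to the ring nitrogen. Within the data shown here, no measured step moves the hydroxyl around its phenyl ring; the single step recorded, a 1.3-fold lower number from compound 1 to compound 2 (0.11 log units; within the scatter), alters the other aryl group and stays within the scatter. Compounds 1 and 2 carry the 4-hydroxyphenyl and sit higher than compound 3, yet they also carry fluoro rather than trifluoromethyl, so the two changes cannot be separated. A modest rise toward those numbers is expected, a 1.5-fold higher number from compound 3 to compound 4 (0.18 log units; within the scatter). Compound 4 is estimated at 4200 nM, with a range of 1800 nM to 9500 nM.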

Compound 4, half-maximal inhibitory concentration: > 50000 nM
Compound 4 gave a limit, no number; the forecaster's own chance of this, stated with the estimate: 3%; at least 11-fold (1.07 log units) between middle value and limit.
By their numbers in this assay, from the lowest: compound 3; then compounds 2 and 1 (each within the scatter of the next). At a limit, above all of these: compound 4.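

In this assay, the value of compound 4 is a limit of the assay, not a number: the limit of > 50000 nM in this assay, at which 1 of the 4 values shown sits. The hydroxyl position on this aryl group, on the carbon next to the ring nitrogen, has a large effect when the other aryl group is 2-(trifluoromethyl)phenyl: an at least 18-fold higher number from compound 3 to compound 4 (1.25 log units; beyond the scatter). The 4-hydroxyphenyl group alone does not bring the limit, since the other aryl group also counts: an at least 8.2-fold higher number from compound 2 to compound 4 (0.91 log units; beyond the scatter), and an at least 6.4-fold higher number from compound 1 to compound 4 (0.80 log units; beyond the scatter).

From the compounds shown here alone, it remains open how 3-hydroxyphenyl behaves alongside 4-fluorophenyl or 2-fluorophenyl. Also open, going by these compounds, is whether a methoxy group or an amine in place of the hydroxyl keeps the number of compound 3.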